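This account rests on a few compounds, and the source may have more. Where it says the series, first, only, none or still open, it means among the compounds named here.

Measured in a functional assay for inhibition, with Homo sapiens as the target; a lower number here means a stronger inhibitor, a higher number a weaker inhibitor:

Compound 1 `Clc1ccccc1C(CC1CCCCC1)Nc1nc2ccccc2o1`: 80 nM
Compound 2 `O=C(O)c1ccc2oc(NC(CC3CCCCC3)c3ccccc3)nc2c1`: 150 nM

These two numbers are all there is to go on so far. Compound 2 gives 150 nM and compound 1 gives 80 nM, and the two values lie within the usual scatter of each other, so neither can be called the better inhibitor.

The next compound is compound 3 `CS(=O)(=O)Nc1ccc2oc(NC(CC3CCCCC3)c3ccccc3)nc2c1`, which keeps everything in compound 2 except one group: methanesulfonamido in place of carboxy on an aromatic carbon.

Among the measured compounds shown here, no two measured compounds differ in just one place, so nothing measured shows directly what this swap does. There is one indirect hint. Though it differs from compound 2 elsewhere too, compound 1 has no carboxy group and still gives 80 nM. On that slim basis, no change beyond the scatter is expected in this assay, although a shift in either direction remains possible. The estimated change is a 1.2-fold lower number from compound 2 to compound 3 (0.06 log units; within the scatter). For compound 3 the expected value is 130 nM, with an estimated range of 40 nM to 420 nM.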

Compound 3, half-maximal inhibitory concentration: 160 nM
Beside the measured number, compound 3's estimate is 1.2-fold (0.09 log units) below it, within the range that was stated.
By their numbers in this assay, from the lowest: compounds 1, 2 and 3 (each within the scatter of the next).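

In this assay, among the compounds shown here, this is the first pair of compounds that differ in only one place, so the effect of a single swap can now be read directly: methanesulfonamido in place of carboxy on an aromatic carbon gives a 1.1-fold higher number from compound 2 to compound 3 (0.03 log units; within the scatter). At this position, therefore, a group of 5 heavy atoms containing sulfur and nitrogen stands in for one of 3 heavy atoms, and the two numbers cannot be told apart, so this assay does not distinguish between these two groups here. No separate measurement accompanies the result that could explain why the two compounds read alike.

The compounds shown leave open what a simple amine or a methyl ester would give on this same aromatic carbon, and whether a group quite unlike these two would also read the same. From the compounds shown here alone, it also remains open whether this swap would give the same result in a compound that carries the chlorine of compound 1, since a single pair says nothing about other versions of the core.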